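Chloro in place of acetoxy: notes toward compound 4

A few compounds are considered here, and "the series" means these few. Any claim that something is new, unique, unknown or untested is made for them only; others in the source may bear on it.

Measured so far:
compound 1, `CC(=O)OCc1ccc2oc(=O)c(C(=O)Oc3cccc(Cl)c3)cc2c1`, 95.2%
compound 2, `CC(=O)OCc1ccc2oc(=O)c(C(=O)Sc3ccccc3)cc2c1`, 89.5%
compound 3, `CC(=O)OCc1ccc2oc(=O)c(C(=O)Sc3cccc(Cl)c3)cc2c1`, 76.5%

In a functional assay on HT-1080 cells (Homo sapiens), read by transwell migration, with a stated time of 24 h, tested at 0.1 uM (a lower number here means a stronger effect, a higher number a weaker effect of the compound at the concentration tested), compound 1 stands highest of the three numbers. The gap to compound 2 is a number 5.7 percentage points lower from compound 1 to compound 2 (within the scatter); the gap to compound 3 is a number 18.7 percentage points lower from compound 1 to compound 3 (beyond the scatter), and between the two sulfur compounds the step is a number 13 percentage points lower from compound 2 to compound 3 (beyond the scatter). All three measured steps concern the group on the carbonyl carbon; the acetoxymethyl chain is kept throughout.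

Compound 4 `O=C(Oc1cccc(Cl)c1)c1cc2cc(CCl)ccc2oc1=O` differs from compound 1 at that untouched chain: chloro in place of acetoxy on a saturated chain carbon bound to an aromatic carbon

Among the measured compounds shown here, no measured step bears on this change, so there is no ground to expect a step beyond the scatter in this assay in either direction. Compound 4 is therefore estimated at 92%, between 76% and 104%, an expected step of a number 3.2 percentage points lower from compound 1 to compound 4 (within the scatter).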

Compound 4, a percentage reported as activity, at one concentration (the size of the read-out at that concentration, not a potency): 98.4%
The estimate for compound 4 lay 6.4 percentage points below the measured number; the range from low to high includes it.
By their numbers in this assay, from the lowest: compound 3; then compounds 2, 1 and 4 (each within the scatter of the next).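

In this assay the change from acetoxymethyl to chloromethyl gives a number 3.2 percentage points higher from compound 1 to compound 4 (within the scatter), so with the 3-chlorophenoxy group kept on the carbonyl carbon, replacing acetoxy with chloro at this chain position produces no step beyond the scatter. No measurement at hand offers an explanation for this result.

From the compounds shown here alone, whether chloromethyl gives the same outcome alongside the (3-chlorophenyl)sulfanyl group of compound 3 remains open. Also open, going by these compounds, is what an amine or a carboxylic acid would give on this saturated chain carbon.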